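Swapping the Aryl Group on the Sulfonyl Sulfur

A few compounds are considered here, and "the series" means these few. Any claim that something is new, unique, unknown or untested is made for them only; others in the source may bear on it.

Measured compounds:
compound 1 `COc1ccc(S(=O)(=O)c2cnc3cc(Cl)ccc3c2N2CCC(C)CC2)cc1Cl`: 93%
compound 2 `COc1cccc(S(=O)(=O)c2cnc3ccc(Cl)cc3c2N2CCC(C)CC2)c1`: 87%

Both were tested in an assay on isolated protein for displacement of a labelled ligand from metabotropic glutamate receptor 5 (Homo sapiens), with a stated time of 60 min, tested at 1 uM; a higher number here means more inhibition at the concentration tested (going by the name of the read-out), a lower number less inhibition. Compound 1 gives 93% and compound 2 gives 87%. Of the two numbers, that of compound 1 is the larger, but the gap to compound 2 falls within the usual scatter, so the two compounds cannot be told apart.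

Compound 3 `CC1CCN(c2c(S(=O)(=O)c3ccc(F)c(F)c3)cnc3cc(Cl)ccc23)CC1` has not yet been measured. It differs from compound 1 in a single place: 3,4-difluorophenyl in place of 3-chloro-4-methoxyphenyl on a sulfonyl sulfur. Going by the values given here, no measured pair shows this change, so nothing is known about its size. In this assay a modest decrease, possibly beyond the scatter, is expected a number 13 percentage points lower from compound 1 to compound 3 (beyond the scatter). Compound 3 is estimated to give 80%, within a range from 55% to 95%.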

Compound 3, a percentage reported as inhibition, at one concentration (the size of the read-out at that concentration, not a potency): 90%
The estimate for compound 3 lay 10 percentage points below the measured number; the measured number falls inside the stated range.
By their numbers in this assay, from the lowest: compounds 2, 3 and 1 (each within the scatter of the next).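

Placing 3,4-difluorophenyl in place of 3-chloro-4-methoxyphenyl on the sulfonyl sulfur gives a number 3 percentage points lower from compound 1 to compound 3 (within the scatter) in this assay, the first direct reading of a change at this position. The methoxy oxygen, the one hydrogen-bond acceptor in the departing group, and the chlorine can therefore both go without a difference that this read-out can detect. No measurement here offers an explanation for this result.

Still open, going by these compounds, is whether an aryl group carrying an amine or a carboxylic acid would fare the same. A single-concentration read-out also leaves any potency difference between these compounds unresolved.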